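This account rests on a few compounds, and the source may have more. Where it says the series, first, only, none or still open, it means among the compounds named here.

Compounds measured:
Compound 1, `O=C(Nc1ccccc1Cl)N1CCN(c2nc(-c3ccc4ccccc4n3)no2)CC1`, in a functional assay on Shh Light II cells (Mus musculus) for inhibition, read by a luciferase reporter (a lower number here means a stronger inhibitor, a higher number a weaker inhibitor), gives 140 nM.
Compound 2, `O=C(NC1CC[S+]([O-])CC1)N1CCC(c2nc(-c3ccc4ccccc4n3)no2)CC1`, in this assay gives 850 nM.
Compound 3, `Cn1c(-c2noc(N3CCN(C(=O)NC4CCCCC4)CC3)n2)nc2ccccc21`, in this assay gives 5 nM.

Compound 2 stands at the highest of these three numbers, so it is the weakest inhibitor of the set in this assay; its nearest neighbour is compound 1, and compound 3 lies furthest from it, both gaps beyond the usual scatter. Compound 4, `O=C(NC1CCCCC1)N1CCC(c2nc(-c3ccc4ccccc4n3)no2)CC1`, has not yet been measured. It differs from compound 2 in one place: a group of 6 heavy atoms (6 carbon; one six-membered non-aromatic ring of carbon only) in place of a group of 7 heavy atoms (5 carbon, 1 oxygen, 1 sulfur; one six-membered non-aromatic ring with 1 hetero atom), on an amide-type nitrogen. The core and the ring carrying the urea are unchanged. For the measured compounds named here, no measured pair shows this exact change, so the expected size of the step rests only on the spread of the three values. Compound 4 is expected to give a lower number than compound 2, with a step of a 3.0-fold lower number from compound 2 to compound 4 (0.48 log units; beyond the scatter), and the estimate for compound 4 is 280 nM, within a range from 70 nM to 1100 nM.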

Compound 4, half-maximal inhibitory concentration: 57 nM
Compound 4: the middle estimate sits 4.9-fold (0.69 log units) above what was measured, and the stated range ends above it.
By their numbers in this assay, from the lowest: compound 3; then compound 4; then compound 1; then compound 2.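

On the amide-type nitrogen, cyclohexyl in place of the six-membered non-aromatic ring with 1 hetero atom gives a 15-fold lower number from compound 2 to compound 4 (1.17 log units; beyond the scatter) in this assay. For the compounds shown here, this is the first step in the set that can be read at a single place, and it shows that this position responds strongly to the group it carries, while the core and the ring carrying the urea stay unchanged. Nothing measured here accounts for the size of this step.

The compounds shown leave open whether the oxygen or the sulfur of the departing ring matters more, a question that a ring with a plain sulfur, a sulfone or a tetrahydropyranyl group could separate. They also leave open whether the same change would have a step of similar size on the core of compound 1.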